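This account rests on a few compounds, and the source may have more. Where it says the series, first, only, none or still open, it means among the compounds named here.

Compound 1 `O=C(c1cccc(Cl)c1)N1CCc2nc(C3(C(=O)Nc4ccc(F)cc4)CCC3)ccc21` and compound 2 `O=C(Nc1ccc(F)cc1)C1(c2ccc3c(n2)CCN3c2ccccn2)CCC1` share one core and differ only in the group on the ring nitrogen, where a 3.6-fold higher number from compound 1 to compound 2 (0.56 log units; beyond the scatter). In an assay on HeLa cells for inhibition of Indoleamine 2,3-dioxygenase 1 (Homo sapiens) (a higher number here means a weaker inhibitor, a lower number a stronger inhibitor), compound 1 gives 3 nM, while compound 2 gives 10.9 nM. Of the two numbers recorded so far, compound 2 has the higher one, so it is the weaker inhibitor of the pair. Compound 3 `O=C(Nc1ccc(F)cc1)C1(c2ccc3c(n2)CCN3c2ccnc(C(F)(F)F)n2)CCC1` keeps everything of compound 2 except the group at that same place: 2-(trifluoromethyl)pyrimidin-4-yl in place of pyridin-2-yl on a nitrogen on an aromatic ring in a ring. Within the data shown here, the single measured step, from compound 1 to compound 2, changed the group at this position and was modest in size, showing that the position tolerates change, but no measured step involves the group that enters here. With nothing closer to lean on, compound 3 is expected to move by a 1.1-fold higher number from compound 2 to compound 3 (0.04 log units; within the scatter) in this assay, a step within the scatter. Compound 3 is therefore estimated at 12 nM, with a range from 4 nM to 40 nM.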

Compound 3, half-maximal inhibitory concentration: 127 nM
Compound 3: the middle estimate sits 11-fold (1.02 log units) below what was measured; measured number above the stated range.
By their numbers in this assay, from the lowest: compound 1; then compound 2; then compound 3.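

The group on this nitrogen is less forgiving than the first step suggested: in this assay, putting 2-(trifluoromethyl)pyrimidin-4-yl in place of pyridin-2-yl gives a 12-fold higher number from compound 2 to compound 3 (1.07 log units; beyond the scatter), even though both groups are six-membered aromatic rings. Measured against the (3-chlorophenyl)carbonyl group, the same new group gives a 42-fold higher number from compound 1 to compound 3 (1.63 log units; beyond the scatter), so among these three compounds the choice of group on this nitrogen can shift the number considerably. Nothing available here bears on what lies behind this loss of strength.

The entering group differs from pyridin-2-yl in two ways at once, a second ring nitrogen and a trifluoromethyl group, and the compounds shown cannot separate these two changes. A plain pyrimidin-4-yl group, or a pyridin-2-yl group carrying trifluoromethyl, would show how much each change contributes.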